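The source may report more compounds than this note shows. Statements on the series, on what has been measured and on what is new or still open speak of the compounds shown alone.

Measured compounds:
compound 1, `O=C(NO)c1ccc(Cn2nnc(-c3ccccn3)n2)cc1`, 9 nM
compound 2, `Cn1c(Sc2ccc(C(=O)NO)cc2)nnc1-c1cccs1`, 8 nM

Of the compounds shown here, two have been measured in an assay on Sf9 cells for inhibition of protein deacetylase HDAC6 (Homo sapiens), read by fluorescence; on this read-out higher numbers stand for weaker inhibition and lower numbers for stronger inhibition. Compound 1 `O=C(NO)c1ccc(Cn2nnc(-c3ccccn3)n2)cc1` gives 9 nM, and compound 2 `Cn1c(Sc2ccc(C(=O)NO)cc2)nnc1-c1cccs1` gives 8 nM. Compound 2 has the lower of the two numbers, but its nearest neighbour is compound 1, and the gap between them lies within the scatter of the assay, so the two are not told apart. For the measured compounds named here, no pair of the measured compounds differs in a single place, so no measured step is available to guide the next change.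

Compound 3 `Cc1cc(-c2nnc(Sc3ccc(C(=O)NO)cc3)n2C)nn1C` is not yet measured. It differs from compound 2 in one place: 1,5-dimethyl-1H-pyrazol-3-yl in place of thiophen-2-yl on an aromatic carbon. The rest of compound 2 is kept. Compounds 1 and 2 differ from each other in several places yet give close numbers, so a single ring exchange of this kind is expected to leave the result in the same region. The step of a 1.5-fold higher number from compound 2 to compound 3 (0.18 log units; within the scatter) that this estimate means is expected to be small, towards a slightly higher number at most, and not clearly beyond the scatter. Compound 3 is therefore estimated at 12 nM, with a range from 4 nM to 40 nM.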

Compound 3, half-maximal inhibitory concentration: 5 nM
The estimate for compound 3 lay 2.4-fold (0.38 log units) above the measured number, within the range that was stated.
By their numbers in this assay, from the lowest: compounds 3, 2 and 1 (each within the scatter of the next).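

In this assay, 1,5-dimethyl-1H-pyrazol-3-yl in place of thiophen-2-yl gives a 1.6-fold lower number from compound 2 to compound 3 (0.20 log units; within the scatter) and so does not tell the two compounds apart. For the compounds shown here, this is the only comparison in the set that changes a single place, and it shows that the position on the aromatic carbon, between two ring nitrogen atoms, takes a group of 7 heavy atoms with 2 hetero atoms in its ring as well as one of 5 heavy atoms with 1 hetero atom, with no step beyond the scatter. No measurement here bears on why the number stays in this region.

Both groups seen at this position are five-membered aromatic rings bound through a ring carbon, which leaves open whether an amine, a carboxylic acid or a longer alkyl chain on the same carbon would keep the number in this region. The compounds shown also do not separate the pyrazole ring from its two methyl groups, and an unsubstituted pyrazol-3-yl at this position would be needed to tell what those methyl groups contribute.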